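Replacing the aryl group on the anilino nitrogen of compound 3

A few compounds are considered here, and "the series" means these few. Any claim that something is new, unique, unknown or untested is made for them only; others in the source may bear on it.

Measured compounds in a functional assay on NCI-H460 cells (Homo sapiens) for antiproliferative activity, read by CCK-8 assay, with a stated time of 72 h, tested at 2 uM; a lower number here means a weaker effect, a higher number a stronger effect of the compound at the concentration tested:
- compound 1, `Cc1ccc(Nc2nc(Cl)nc3c2ncn3Cc2ccc(C(=O)Nc3ccccc3N)cc2)cc1`: 67.3%
- compound 2, `Nc1ccccc1NC(=O)c1ccc(Cn2cnc3c(Nc4ccccc4)nc(Cl)nc32)cc1`: 42.7%
- compound 3, `Nc1ccccc1NC(=O)c1ccc(Cn2cnc3c(Nc4ccc(-c5ccccn5)cc4)nc(Cl)nc32)cc1`: 18.1%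

Compound 3 stands lowest of the three numbers in this assay. The nearest is compound 2, a number 24.6 percentage points lower from compound 2 to compound 3 (beyond the scatter); the furthest is compound 1, a number 49.2 percentage points lower from compound 1 to compound 3 (beyond the scatter). Both steps lie beyond the scatter, so compound 3 is the weakest measured compound on these data.

Compound 4, `Nc1ccccc1NC(=O)c1ccc(Cn2cnc3c(Nc4cccc(OC(F)(F)F)c4)nc(Cl)nc32)cc1`, is not yet measured. It differs from compound 3 in one place: 3-(trifluoromethoxy)phenyl in place of 4-(pyridin-2-yl)phenyl on a nitrogen on an aromatic ring.

Among the compounds with values here, two measured steps bear on this change. Going from compound 2 to compound 3 puts pyridin-2-yl in place of hydrogen on an aromatic carbon, and the number falls by a modest amount. Going from compound 1 to compound 3 puts pyridin-2-yl in place of methyl, and the fall is large. Within the data shown here, compound 4 removes the pyridin-2-yl entirely, so the step back toward compound 2 is the better guide; no measured compound carries 3-(trifluoromethoxy)phenyl, so what that group adds is unknown. A rise in this assay beyond the scatter is therefore expected for compound 4, a number 25.9 percentage points higher from compound 3 to compound 4 (beyond the scatter), with the wide range reflecting the untested group. Compound 4 is estimated at 44%, between 24% and 64%.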

Compound 4, a percentage reported as inhibition, at one concentration (the size of the read-out at that concentration, not a potency): 47.7%
Compound 4: middle estimate off by 3.7 percentage points, on the low side; measured number inside the range.
By their numbers in this assay, from the lowest: compound 3; then compounds 2 and 4 (each within the scatter of the next); then compound 1.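

In this assay, the change on the nitrogen on an aromatic ring gives a number 29.6 percentage points higher from compound 3 to compound 4 (beyond the scatter) and so shows that the low reading of compound 3 does not extend to every large aryl group here: 3-(trifluoromethoxy)phenyl and 4-(pyridin-2-yl)phenyl are close in heavy-atom count, so heavy-atom count does not follow the read-out for this pair. Against the unsubstituted phenyl, the new group gives a number 5 percentage points higher from compound 2 to compound 4 (within the scatter) and thus no resolved gain, while against 4-methylphenyl it gives a number 19.6 percentage points lower from compound 1 to compound 4 (beyond the scatter) and leaves compound 1 the strongest of the four at the concentration tested. No accompanying data bear on why these aryl groups differ.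

Going by these compounds, it remains open whether the read-out of compound 3 depends on the pyridine nitrogen or on the second ring as such, which 4-biphenylyl would separate, and whether 4-(trifluoromethoxy)phenyl or 3-methylphenyl would read differently from their positional isomers. These are single-concentration read-outs, so the order of the four compounds does not settle how their potencies compare.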